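The source may report more compounds than this note shows. Statements on the series, on what has been measured and on what is new or still open speak of the compounds shown alone.

Measured in an ADME assay on liver (Mus musculus) for metabolic stability, read by LC-MS, using microsomes and NADPH; a lower number here means that less of the compound is left, a higher number that more of the compound is left:
- compound 1 `Cc1cc(CN(C)C(CC(=O)O)c2ccc(Cl)cc2)ccc1OCCn1c(=O)ccn(C)c1=O`: 68%
- compound 2 `COc1cc(CN(CC(C)C)C(CC(=O)O)c2ccc3c(c2)CCO3)ccc1OCCN1C(=O)CCC1=O`: 100%
- compound 3 `COc1cc(CN(CC(C)C)C(CC(=O)O)c2ccc(Cl)cc2)ccc1OCCN1C(=O)CCC1=O`: 69%

Compound 3, at 69%, is level within the scatter with compound 1, at 68%, and clearly under compound 2, at 100%. Compound 4 `COc1cc(CN(CC(C)C)C(CC(=O)O)c2ccc(Cl)c(Cl)c2)ccc1OCCN1C(=O)CCC1=O` differs from compound 3 by one change, (chloro in place of hydrogen on an aromatic carbon), taking 4-chlorophenyl to 3,4-dichlorophenyl. Within the data shown here, only one measured step touches this group: a number 31 percentage points lower from compound 2 to compound 3 (beyond the scatter). Among the measured compounds shown here, that large step exchanges a whole ring group, so it says little about one added chloro, and no measured step adds a chloro alone. A small fall is therefore expected, with the estimated step of a number 4 percentage points lower from compound 3 to compound 4 (within the scatter) staying within the scatter. For compound 4 the expected value is 65%, with an estimated range of 45% to 85%.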

Compound 4, percent of the compound remaining: 49%
For compound 4 the middle estimate is 16 percentage points above the measured one, within the range that was stated.
By their numbers in this assay, from the lowest: compound 4; then compounds 1 and 3 (each within the scatter of the next); then compound 2.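

In this assay, the chloro in place of hydrogen on an aromatic carbon, taking 4-chlorophenyl to 3,4-dichlorophenyl, gives a number 20 percentage points lower from compound 3 to compound 4 (beyond the scatter), so this single added atom moves the number by itself, without a whole ring group being exchanged. The gap to the ring group of compound 2 widens accordingly, to a number 51 percentage points lower from compound 2 to compound 4 (beyond the scatter). Nothing measured here accounts for the fall. As far as these compounds go, whether a fluoro or a methoxy on that same carbon would lower the number as far remains open.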